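The source may hold more compounds than are shown below. What is called first, only, known or untested is meant among the compounds shown, and "the series" means these compounds.

Compound 2 `C#CCSc1nc(Nc2ccc(Cl)cc2)c2ccncc2n1` carries the only number shown in a functional assay on HepG2 cells (Homo sapiens) for inhibition, read by MTT assay, with a stated time of 72 h (on this read-out higher numbers stand for weaker inhibition and lower numbers for stronger inhibition), where compound 2 gives 36700 nM. Compound 1 `C#CCSc1nc(NCCC(C)C)c2ccncc2n1` reaches only a limit of this assay, > 80000 nM. Among the compounds with values here, the single measured step, an at least 2.1-fold lower number from compound 1 to compound 2 (0.33 log units; beyond the scatter), concerns a different part of the structure. Compound 3 `C#CCSc1nc(Nc2ccc(Br)cc2)c2ccncc2n1` differs from compound 2 by bromo in place of chloro on an aromatic carbon. Within the data shown here, no measured step bears on an exchange of one halogen for another, so compound 3 is expected to show no step beyond the scatter in this assay. Compound 3 is therefore estimated at 30000 nM, within 12000 nM to 80000 nM. That estimate means an expected step of a 1.2-fold lower number from compound 2 to compound 3 (0.09 log units; within the scatter).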

Compound 3, half-maximal inhibitory concentration: 56200 nM
Estimate against measurement, compound 3: 1.9-fold (0.27 log units) below; measured number inside the range.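

In this assay, the exchange of chloro for bromo on the aromatic carbon para to a large group gives a 1.5-fold higher number from compound 2 to compound 3 (0.19 log units; within the scatter), so the two halogens are not told apart here. Against isopentyl, 4-bromophenyl gives an at least 1.4-fold lower number from compound 1 to compound 3 (0.15 log units; that floor lies within the scatter), so it does not by itself confirm the step seen with 4-chlorophenyl. That step has only a floor because compound 1 stands at a limit: the limit of > 80000 nM in this assay, at which 1 of the 3 values shown sits.

On these data alone, whether fluoro, methoxy, an amine or a carboxylic acid at this place would shift the number remains open.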